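Acylguanidine series: shortening the amine-bound chain

The compounds below may be only part of what the source reports. "The series", "measured", "known", "first", "only" and "open" are said of these compounds alone.

Of the compounds shown here, two carry numbers so far. Compound 1 `CCN(CC)CCCC(C)/N=C(/N)NC(=O)c1cccc(F)c1CCc1ccc2ccccc2c1` in a functional assay for antagonist activity at Melanocortin receptor 4 (Homo sapiens), read by cAMP accumulation (on this read-out lower numbers stand for stronger inhibition and higher numbers for weaker inhibition), gives 1800 nM. Compound 2 `COc1ccc(Br)cc1CCc1c(F)cccc1C(=O)/N=C(\N)NCCCN1CCCCC1` in this assay gives 330 nM, the lowest of the two numbers; compound 1 stands at a higher number, and that gap lies beyond the scatter. Compound 3 `COc1ccc(Br)cc1CCc1c(F)cccc1C(=O)/N=C(\N)NCC(C)C` is not yet measured. It differs from compound 2 by isopropyl in place of 2-(piperidin-1-yl)ethyl on a saturated chain carbon bound to an amine nitrogen. Going by the values given here, no pair of measured compounds shows this change, so its size has no precedent in the data. Both measured compounds carry a ring nitrogen on that chain; compound 3 drops it. A move toward a higher number, of a size beyond the scatter, is the expectation. Compound 3 in this assay is expected to give 2500 nM, within 600 nM to 10000 nM. The expected step from a 7.6-fold higher number from compound 2 to compound 3 (0.88 log units; beyond the scatter) runs toward weaker inhibition.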

Compound 3, half-maximal inhibitory concentration: 8500 nM
The estimate for compound 3 lay 3.4-fold (0.53 log units) below the measured number; low and high end bracket the measured number.
By their numbers in this assay, from the lowest: compound 2; then compound 1; then compound 3.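

In this assay, going by these compounds alone, isopropyl in place of 2-(piperidin-1-yl)ethyl on a saturated chain carbon bound to an amine nitrogen gives a 26-fold higher number from compound 2 to compound 3 (1.41 log units; beyond the scatter), the first change in one place that can be read. This position is therefore sensitive to the group it carries: the isobutyl chain does not stand in for the 3-(piperidin-1-yl)propyl chain without a large move toward weaker inhibition. Nothing at hand accounts for the size of this step.

The change removes the ring, its nitrogen and chain length together, so the compounds shown do not separate these contributions. A 3-(dimethylamino)propyl chain would keep the amine without the ring, and a 3-cyclohexylpropyl chain would keep a six-membered ring without the nitrogen.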